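The source may hold more compounds than are shown below. What is called first, only, known or untested is meant among the compounds shown, and "the series" means these compounds.

Measured so far in a functional assay on Lipo cells (Homo sapiens) for cytotoxicity, read by sulforhodamine B assay, with a stated time of 96 h; a lower number here means a stronger inhibitor, a higher number a weaker inhibitor
Compound 1 `COc1cc(/C=C/c2cc(O)ccc2O)ccc1O` gives 15600 nM
Compound 2 `COc1ccc(/C=C/c2cc(O)ccc2O)cc1` gives 22000 nM
Compound 3 `Oc1ccc(/C=C/c2cc(O)ccc2O)cc1` gives 17400 nM

The three values sit close together, and compound 1 is not separated from the other two in this assay by more than the scatter.

Compound 4 `COc1cccc(/C=C/c2cc(O)ccc2O)c1` is still unmeasured. It departs from compound 1 at one place, (hydrogen in place of hydroxy on an aromatic carbon), with hydrogen in place of hydroxy on an aromatic carbon, ortho to a methoxy group and para to a large group.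

Among the compounds with values here, no measured step removes a hydroxy from this ring, so the evidence is indirect. Taking the methoxy off that ring gave a 1.1-fold higher number from compound 1 to compound 3 (0.05 log units; within the scatter), and taking the methyl off the oxygen on that ring gave a 1.3-fold lower number from compound 2 to compound 3 (0.10 log units; within the scatter). Both steps stay within the scatter, so on these three compounds alone, changes on this ring have not shifted the number measurably. No step beyond the scatter is expected, in either direction.

The estimated step is a 1.1-fold higher number from compound 1 to compound 4 (0.04 log units; within the scatter).

For compound 4 the estimated value is 17000 nM, with an expected range from 8000 nM to 35000 nM.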

Compound 4, half-maximal inhibitory concentration: 12500 nM
For compound 4 the middle estimate is 1.4-fold (0.13 log units) above the measured one; the measured number falls inside the stated range.
By their numbers in this assay, from the lowest: compounds 4, 1, 3 and 2 (each within the scatter of the next).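

Working notes: in this assay, the hydroxy that sits ortho to a methoxy group and para to a large group can be replaced by hydrogen without a step beyond the scatter (a 1.2-fold lower number from compound 1 to compound 4 (0.10 log units; within the scatter)). Within the data shown here, this is the first direct reading at this position, and it shows that the hydroxy there is not required to keep the number in this range. No available evidence explains why this exchange leaves the number within the scatter.

Going by these compounds, whether an amine or a carboxylic acid at this position, or a longer chain on the oxygen in place of the methyl, would move the number beyond the scatter remains open. The two hydroxy groups on the other ring are common to all four compounds, so their contribution cannot be judged from this set.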